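The source may hold more compounds than are shown below. What is called first, only, known or untested is meant among the compounds shown, and "the series" means these compounds.

Compound 2 `Cc1ccc(Cn2cc(CSC(=S)N3CCN(C(N)=O)CC3)nn2)cc1`: > 128000 nM
Compound 1 `CCNC(=O)N1CCN(C(=S)SCc2cn(Cc3ccccc3F)nn2)CC1`: 5760 nM

In a functional assay on MCF7 cells (Homo sapiens) for cytotoxicity, read by MTT assay, with a stated time of 72 h (a lower number here means a stronger inhibitor, a higher number a weaker inhibitor), compound 2 gives only a limit, > 128000 nM, not a number; this is the limit of > 128000 nM in this assay, at which 1 of the 2 values shown sits. Compound 1 gives 5760 nM in this assay. For the measured compounds named here, these two differ in two places, so their values show only that one has a number and the other a limit.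

Compound 3 `CCNC(=O)N1CCN(C(=S)SCc2cn(Cc3ccc(C)cc3)nn2)CC1` is not yet measured. From compound 2 the change is ethyl in place of hydrogen on an amide-type nitrogen. Going by the values given here, no measured step of this kind exists here, so its size is uncertain. A gain beyond the scatter is expected, an at least 5.1-fold lower number from compound 2 to compound 3 (0.70 log units; beyond the scatter). For compound 3 the estimate is 25000 nM, between 5000 nM and 128000 nM.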

Compound 3, half-maximal inhibitory concentration: > 128000 nM
Compound 3: a limit, no number; the forecaster's own chance of this, stated with the estimate: 35%; middle value at least 5.1-fold (0.70 log units) from the limit.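

In this assay compound 3 gives > 128000 nM, a limit and not a number. With the ethyl group kept, 4-methylphenyl in place of 2-fluorophenyl on a saturated chain carbon bound to an aromatic nitrogen gives an at least 22-fold higher number from compound 1 to compound 3 (1.34 log units; beyond the scatter), so this aryl group matters strongly here. The effect of ethyl in place of hydrogen cannot be read, since both compounds rest on the same limit: the limit of > 128000 nM in this assay, at which 2 of the 3 values shown sit.

On these data alone, whether the fluorine or the missing methyl drives this step stays open. A plain phenyl group or a 4-chlorophenyl group on that carbon could separate the two.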